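The source may report more compounds than this note shows. Statements on the series, on what has been measured and on what is new or still open speak of the compounds shown alone.

Of the compounds shown here, three on the shared core have been read in a functional assay on SMMC-7721 cells (Homo sapiens) for antiproliferative activity, read by MTT assay, with a stated time of 48 h (a higher number here means a weaker inhibitor, a lower number a stronger inhibitor), so far. Compound 1 `CC(C)=CCC[C@]1(C)/C=C/[C@@H](OC(=O)C=C(C)C)[C@](C)(O)/C=C/C(=O)/C(CN(C(C)C)C(C)C)=C\C1`, with (diisopropylamino)methyl, gives 340 nM and compound 2 `CC[Si](CC)(CC)C/C1=C/C[C@](C)(CCC=C(C)C)/C=C/[C@@H](OC(=O)C=C(C)C)[C@](C)(O)/C=C/C1=O` gives 3460 nM. Compound 3 `CC(C)=CCC[C@]1(C)/C=C/[C@@H](OC(=O)C=C(C)C)[C@](C)(O)/C=C/C(=O)/C(C(=O)N(C(C)C)C(C)C)=C\C1`, with diisopropylcarbamoyl, gives 17200 nM, the highest number of the three and thus the weakest inhibitor here.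

Compound 4 `CC(C)=CCC[C@]1(C)/C=C/[C@@H](OC(=O)C=C(C)C)[C@](C)(O)/C=C/C(=O)/C(C(=O)N2CCCC2)=C\C1` differs from compound 3 in one place, with pyrrolidin-1-yl in place of diisopropylamino on a carbonyl carbon.

Among the measured compounds shown here, no measured step changes the group on this carbonyl carbon, so the evidence is indirect. The steps at hand all concern the group on the double-bonded ring carbon: the large 51-fold higher number from compound 1 to compound 3 (1.70 log units; beyond the scatter), the large 10-fold higher number from compound 1 to compound 2 (1.01 log units; beyond the scatter) and the modest 5.0-fold higher number from compound 2 to compound 3 (0.70 log units; beyond the scatter). They show that the number in this assay can move far in this series, but they do not give the size of this particular change. Compound 4 keeps the carbonyl of compound 3, so only a small step is expected, either within the scatter or modestly towards a lower number. The expected step is a 1.6-fold lower number from compound 3 to compound 4 (0.19 log units; within the scatter), with wide uncertainty. For compound 4 the estimated value is 11000 nM, with an expected range of 3500 nM to 35000 nM.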

Compound 4, half-maximal inhibitory concentration: 14900 nM
Estimate against measurement, compound 4: 1.4-fold (0.13 log units) below, within the range that was stated.
By their numbers in this assay, from the lowest: compound 1; then compound 2; then compounds 4 and 3 (each within the scatter of the next).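

In this assay the amine on the carbonyl carbon can be exchanged with almost no consequence (a 1.2-fold lower number from compound 3 to compound 4 (0.06 log units; within the scatter)), so an open diisopropylamino and a ring-closed pyrrolidin-1-yl cannot be told apart at this place. The distance from compound 1 persists after the exchange (a 44-fold higher number from compound 1 to compound 4 (1.64 log units; beyond the scatter)), and compound 2 also remains separated from compound 4 (a 4.3-fold higher number from compound 2 to compound 4 (0.63 log units; beyond the scatter)), so among these compounds the change of the whole group on the double-bonded ring carbon moves the number far more than the change on the carbonyl carbon does. No supporting measurement accounts for either the flat amide pair or the distance from compound 1.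

Open, from the compounds shown here alone, is whether the flat response extends to other groups on the carbonyl carbon, such as dimethylamino, morpholine or a hydroxyl that would give a carboxylic acid. Also open, going by these compounds, is whether (pyrrolidin-1-yl)methyl on the double-bonded ring carbon would track the (diisopropylamino)methyl of compound 1, which would show whether the exchange of amines is equally silent once the carbonyl is absent.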